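The source may hold more compounds than are shown below. What is called first, only, known or untested is meant among the compounds shown, and "the series" means these compounds.

Measured compounds:
- compound 1, `COc1ccc(-c2nc(C(F)(F)F)sc2N2CCN(C(=O)Cn3cnc4cccnc43)[C@H](C)C2)cc1`: 13 nM
- compound 2, `COc1ncc(-c2nc(C(F)(F)F)sc2N2CCN(C(=O)Cn3cnc4cccnc43)[C@H](C)C2)cn1`: 3.8 nM
- compound 3, `Cc1ncc(-c2nc(C(F)(F)F)sc2N2CCN(C(=O)Cn3cnc4cccnc43)[C@H](C)C2)cn1`: 3.6 nM

All three share one core and differ only in the aryl group. In a functional assay on CHO-K1 cells for antagonist activity at C-X-C chemokine receptor type 3 (Homo sapiens), read by FLIPR, with a stated time of 10 min (a higher number here means a weaker inhibitor, a lower number a stronger inhibitor), compound 3 gives the lowest of the three numbers, but its neighbour compound 2 sits within the scatter of it, so the two cannot be ranked; only compound 1 is clearly apart, with a 3.6-fold lower number from compound 1 to compound 3 (0.56 log units; beyond the scatter) and a 3.4-fold lower number from compound 1 to compound 2 (0.53 log units; beyond the scatter).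

Compound 4, `COCCOc1ncc(-c2nc(C(F)(F)F)sc2N2CCN(C(=O)Cn3cnc4cccnc43)[C@H](C)C2)cn1`, is the next step from compound 3: 2-methoxyethoxy in place of methyl on an aromatic carbon. Among the measured compounds shown here, the one step that bears directly on this position is a 1.1-fold lower number from compound 2 to compound 3 (0.02 log units; within the scatter), which shows that exchanging methoxy for methyl on that aromatic carbon leaves this assay unchanged. The two larger steps concern the ring itself, which compound 4 keeps. The pyrimidine is retained here and only the group on it grows, so no step beyond the scatter is expected, with a slight lean toward a higher number as the longer chain replaces the small group. The estimate for compound 4 is 5.5 nM, range 2 nM to 16 nM, corresponding to an expected 1.5-fold higher number from compound 3 to compound 4 (0.18 log units; within the scatter).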

Compound 4, half-maximal inhibitory concentration: 4.7 nM
Compound 4: middle estimate off by 1.2-fold (0.07 log units), on the high side, and the stated range covers the measured number.
By their numbers in this assay, from the lowest: compounds 3, 2 and 4 (each within the scatter of the next); then compound 1.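

In this assay, the aromatic carbon between two ring nitrogen atoms accepts far more than the exchange of methoxy for methyl could show: 2-methoxyethoxy in place of methyl gives no readable change (a 1.3-fold higher number from compound 3 to compound 4 (0.12 log units; within the scatter)), and the same holds against the methoxy group of compound 2 (a 1.2-fold higher number from compound 2 to compound 4 (0.09 log units; within the scatter)). The advantage over the 4-methoxyphenyl group also persists with this longer ether chain in place (a 2.8-fold lower number from compound 1 to compound 4 (0.44 log units; beyond the scatter)). No measurement at hand explains why the number stays flat across these groups at this position.

From the compounds shown here alone, whether the same carbon also accepts an amine, a carboxylic acid or a longer chain ending in a hydroxyl group stays open. Also open, going by these compounds, is whether 2-methoxyethoxy behaves alike on a phenyl ring.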